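Removing a fluorine: a small change on a weak pair

This account rests on a few compounds, and the source may have more. Where it says the series, first, only, none or still open, it means among the compounds named here.

Of the compounds shown here, two of a shared core have been tested in a functional assay on KB cells (Homo sapiens) for inhibition, read by MTT assay, with a stated time of 24 h, tested at 10 uM; on this read-out lower numbers stand for less inhibition of growth and higher numbers for more inhibition of growth at the one concentration tested. Compound 1 `CS(=O)(=O)c1ccc(-c2cnc3[nH]cc(-c4nnc(-c5ccncc5)o4)c(=O)c3c2)cc1` gives 3.02% in this assay. Compound 2 `CS(=O)(=O)c1ccc(-c2cnc3[nH]cc(-c4nnc(-c5ccc(F)cc5)o4)c(=O)c3c2)cc1` carries a 4-fluorophenyl group in place of the pyridin-4-yl group of compound 1; in this assay compound 2 gives 7.58%. Within the data shown here, compound 2 thus stands highest of the two numbers, but the only measured step, a number 4.6 percentage points higher from compound 1 to compound 2 (within the scatter), lies within the scatter, so the two values cannot be told apart.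

Compound 3 `CS(=O)(=O)c1ccc(-c2cnc3[nH]cc(-c4nnc(-c5ccccc5)o4)c(=O)c3c2)cc1` is not yet measured. It differs from compound 2 by hydrogen in place of fluoro on an aromatic carbon. Among the measured compounds shown here, no measured step removes a fluoro group in this way; the one step that exists, from compound 1 to compound 2, exchanges a whole ring and was itself within the scatter. Both measured numbers are low, and nothing in them points to a change of size. For compound 3 a step of a number 1.6 percentage points lower from compound 2 to compound 3 (within the scatter) is expected, which is no step beyond the scatter. Compound 3 is therefore estimated to give 6% in this assay, with a range from -4% to 16%.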

Compound 3, percent growth inhibition at one concentration: 5.2%
Compound 3: the middle estimate sits 0.8 percentage points above what was measured; low and high end bracket the measured number.
By their numbers in this assay, from the lowest: compounds 1, 3 and 2 (each within the scatter of the next).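

The fluoro group, which sits on an aromatic carbon para to a large group, now has a direct test of its own in this assay: hydrogen in its place gives a number 2.4 percentage points lower from compound 2 to compound 3 (within the scatter), so compound 2 and compound 3 cannot be told apart on this read-out. The ring exchange also gains a second reading without fluorine in the picture, as phenyl in place of pyridin-4-yl gives a number 2.2 percentage points higher from compound 1 to compound 3 (within the scatter), and this pair cannot be told apart either. All three compounds therefore form one group within the scatter at the single concentration tested, and no measurement of any other kind is available to explain the result.

Still open, going by these compounds, is whether a different group on this same aromatic carbon, such as an amine, a carboxylic acid or a longer chain, would give a number beyond the scatter of these three compounds. Also open, on these data alone, is how compound 1, compound 2 and compound 3 would compare across a range of concentrations, which a reading at one concentration cannot show.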